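This account rests on a few compounds, and the source may have more. Where it says the series, first, only, none or still open, it means among the compounds named here.

Measured compounds in a functional assay on ileum for inhibition of histamine H1 receptor (Cavia porcellus); a higher number here means a weaker inhibitor, a lower number a stronger inhibitor:
Compound 1, `CCSCCn1c(N2CCN(C)CC2)nc2ccccc21`, gives 19 nM.
Compound 2, `COCCCn1c(N2CCN(C)CC2)nc2ccccc21`, gives 860 nM.
Compound 3, `CN1CCN(c2nc3ccccc3[nH]2)CC1`, gives > 3000 nM, which is a limit of the assay and not a number.

Compound 3 thus stands at the weak end of the three, with only a limit known for it (the limit of > 3000 nM in this assay, at which 1 of the 3 values shown sits). The unmeasured compound 4, `CCCC(C)Cn1c(N2CCN(C)CC2)nc2ccccc21`, differs from it in one place: 2-methylpentyl in place of hydrogen on an aromatic nitrogen. Two measured steps run the opposite way across the same position. Going an at least 150-fold higher number from compound 1 to compound 3 (2.19 log units; beyond the scatter), the loss of the 2-(ethylsulfanyl)ethyl chain cost heavily; going an at least 3.4-fold higher number from compound 2 to compound 3 (0.54 log units; beyond the scatter), the loss of the 3-methoxypropyl chain cost less, though still beyond the scatter. Both point the same way: adding a chain to that nitrogen of compound 3 should lower the number in this assay by a large margin. Compound 4 is therefore expected to show an at least 20-fold lower number from compound 3 to compound 4 (1.30 log units; beyond the scatter), a clearly stronger inhibitor than compound 3. The estimated value for compound 4 in this assay is 150 nM, with a range from 30 nM to 1500 nM.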

Compound 4, half-maximal inhibitory concentration: 500 nM
Estimate against measurement, compound 4: 3.3-fold (0.52 log units) below, and the stated range covers the measured number.
By their numbers in this assay, from the lowest: compound 1; then compounds 4 and 2 (each within the scatter of the next). At a limit, above all of these: compound 3.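

In this assay, the all-carbon 2-methylpentyl chain on the aromatic nitrogen gives an at least 6.0-fold lower number from compound 3 to compound 4 (0.77 log units; beyond the scatter), so a chain there needs no sulfur or oxygen to lower the number. Putting it in place of the 3-methoxypropyl chain gives a 1.7-fold lower number from compound 2 to compound 4 (0.24 log units; within the scatter), which leaves those two chains indistinguishable, whereas putting it in place of the 2-(ethylsulfanyl)ethyl chain gives a 26-fold higher number from compound 1 to compound 4 (1.42 log units; beyond the scatter), so among the three chains shown only that one stands apart. Compound 3 is known only as a limit of the assay, so the first of these steps has no upper bound: the limit of > 3000 nM in this assay, at which 1 of the 4 values shown sits.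

Going by these compounds, what a 2-ethoxyethyl chain, the oxygen counterpart of the 2-(ethylsulfanyl)ethyl chain, would give remains open. So does the effect of an amine at the end of the chain.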